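The compounds below may be only part of what the source reports. "The series", "measured", "known", "first", "only" and "open" are said of these compounds alone.

Of the compounds shown here, two have so far been measured in a functional assay on HL-60 cells (Homo sapiens) for antiproliferative activity, read by XTT assay, with a stated time of 72 h; on this read-out lower numbers stand for stronger inhibition and higher numbers for weaker inhibition. Compound 1 `COc1ncnc2c1c(-c1ccoc1)cn2[C@@H]1O[C@H](CO)[C@@H](O)[C@H]1O` gives 150 nM in this assay. Compound 2 `CN(C)c1ncnc2c1c(-c1ccoc1)cn2[C@@H]1O[C@H](CO)[C@@H](O)[C@H]1O`, in which dimethylamino stands in place of methoxy on an aromatic carbon, gives 1160 nM in this assay. This is the higher of the two numbers measured: a 7.7-fold higher number from compound 1 to compound 2 (0.89 log units; beyond the scatter).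

Compound 3 `CN(C)c1ncnc2c1c(-c1cccs1)cn2[C@@H]1O[C@H](CO)[C@@H](O)[C@H]1O` differs from compound 2 in one place only: thiophen-2-yl in place of furan-3-yl on an aromatic carbon. Among the measured compounds shown here, the single measured step concerns a different group at a different place, so no measured step bears directly on this exchange of one five-membered aromatic ring for another, and nothing in the data shows how large such an exchange tends to be. With only this to go on, the expected step in this assay is none beyond the scatter, in either direction. The step that this estimate means, a 1.1-fold lower number from compound 2 to compound 3 (0.02 log units; within the scatter), is expected to lie within the usual scatter. Compound 3 is therefore estimated at 1100 nM, with a range from 400 nM to 3200 nM that is kept wide to reflect the lack of any directly comparable pair.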

Compound 3, half-maximal inhibitory concentration: 11800 nM
Beside the measured number, compound 3's estimate is 11-fold (1.03 log units) below it, outside the stated range (above it).
By their numbers in this assay, from the lowest: compound 1; then compound 2; then compound 3.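

In this assay, the aromatic carbon two ring bonds from the ring nitrogen proves sensitive to which ring it carries, with a 10-fold higher number from compound 2 to compound 3 (1.01 log units; beyond the scatter) as the result of exchanging one ring for another. By the counts alone, furan-3-yl and thiophen-2-yl look alike, each a five-membered aromatic ring with the same number of heavy atoms, a single hetero atom and no net charge, so a swap that seems minor on paper can still weaken activity well beyond the scatter. No measurement shown here explains why this step is so large.

This exchange changes two things at once, the hetero atom (oxygen to sulfur) and the ring atom through which the ring is attached, so the compounds shown leave open which of the two matters; thiophen-3-yl or furan-2-yl on the same core would pull them apart. Also open, as far as these compounds go, are how a phenyl ring or a small amine would read at this carbon, and whether thiophen-2-yl would cost as much alongside the methoxy group of compound 1.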